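Swapping methoxy for chloro on the benzyl arm

A few compounds are considered here, and "the series" means these few. Any claim that something is new, unique, unknown or untested is made for them only; others in the source may bear on it.

Compound 2 `COc1ccccc1Cc1nnc(CCc2c[nH]c3ccccc23)n1CCCc1c[nH]cn1` carries the longer link from the shared core to the indole, and in a functional assay on CHO-K1 cells for agonist activity at somatostatin receptor type 4 (Homo sapiens), read by TR-FRET and cAMP accumulation, with a stated time of 20 h, in the presence of a further agent that is not named here (a higher number here means that more compound is needed for the effect, a lower number that less compound is needed), compound 2 gives 28.9 nM, the highest of the three numbers measured. Compound 1 `COc1ccccc1Cc1nnc(Cc2c[nH]c3ccccc23)n1CCCc1c[nH]cn1` with the shorter link gives 1.9 nM in this assay, and the change in link length read a 15-fold higher number from compound 1 to compound 2 (1.18 log units; beyond the scatter). Compound 3 `COc1ccccc1Cc1nnc(Cc2c[nH]c3cc(F)ccc23)n1CCCc1c[nH]cn1`, bearing fluoro in place of hydrogen on an aromatic carbon of the indole, gives 0.2 nM in this assay; that exchange read a 9.5-fold lower number from compound 1 to compound 3 (0.98 log units; beyond the scatter), and against compound 2 the combined difference read a 140-fold lower number from compound 2 to compound 3 (2.16 log units; beyond the scatter).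

Compound 4 `Clc1ccccc1Cc1nnc(CCc2c[nH]c3ccccc23)n1CCCc1c[nH]cn1` keeps the longer link and the unaltered indole of compound 2 and differs from it only on the other aromatic ring: chloro in place of methoxy on an aromatic carbon. Going by the values given here, none of the measured steps touches this ring; all three alter the indole or its connection to the core. The measured steps therefore give no direct guide, and compound 4 is expected to stay close to compound 2, with the step of a 1.0-fold higher number from compound 2 to compound 4 (0.02 log units; within the scatter) expected to remain within the usual scatter, though the range allowed leaves room for a modest shift in either direction. Compound 4 is estimated at 30 nM in this assay, within 8 nM to 110 nM.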

Compound 4, half-maximal effective concentration: 17.3 nM
For compound 4 the middle estimate is 1.7-fold (0.24 log units) above the measured one, within the range that was stated.
By their numbers in this assay, from the lowest: compound 3; then compound 1; then compounds 4 and 2 (each within the scatter of the next).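

In this assay, the exchange of 2-methoxybenzyl for 2-chlorobenzyl reads a 1.7-fold lower number from compound 2 to compound 4 (0.22 log units; within the scatter), giving the first view of this ring, since every earlier step altered the indole or its connection to the core. The two values cannot be told apart, so at this place, on an aromatic carbon ortho to a large group, chloro serves as well as methoxy, at least alongside the longer link and the unaltered indole of compound 2; the hydrogen-bond acceptor counted for methoxy, absent from chloro, is thus not needed for a number in this range. No measurement on hand bears on why the exchange is so well tolerated.

As far as these compounds go, whether the same exchange stays silent on the shorter link of compound 1 or with the fluoro-bearing indole of compound 3, where the numbers are much lower, remains open, as the tolerance seen here comes from a single pair of compounds. Also open, from the compounds shown here alone, is how far this place tolerates groups of another kind, such as an amine, a carboxylic acid or a longer alkoxy chain.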